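The source may report more compounds than this note shows. Statements on the series, on what has been measured and on what is new or still open speak of the compounds shown alone.

Of the compounds shown here, two have been tested in a functional assay on B16-F10 cells (Mus musculus) for cytotoxicity, read by MTT assay, with a stated time of 48 h; a lower number here means a stronger inhibitor, a higher number a weaker inhibitor. Compound 1 `S=C(Nc1ccc(Cl)cc1)Nc1nc2ccccc2s1` gives > 50000 nM, which is a limit of the assay rather than a number. Compound 2 `Cc1ccc2nc(Nc3nc4ccccc4s3)sc2c1` gives > 50000 nM, again a limit, so it stands at the limit of > 50000 nM in this assay, at which 2 of the 2 values shown sit. Compound 3 `Clc1ccc2nc(Nc3nc4ccccc4s3)sc2c1` differs from compound 2 by chloro in place of methyl on an aromatic carbon. No measured step sizes this change; with both known values at the limit, no move beyond the usual scatter is expected, and the step that the limit leaves unreadable from compound 2 to compound 3 is an estimate. Compound 3 is expected to give 60000 nM, between 20000 nM and 200000 nM, most likely reported only as a limit.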

Compound 3, half-maximal inhibitory concentration: > 50000 nM
Compound 3 was reported as a limit (the forecaster's own chance of this, stated with the estimate: 80%); the middle value lies beyond the limit too.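

Compound 2 and compound 3 both stop at a limit rather than a number, so chloro in place of methyl gives no readable step: the limit of > 50000 nM in this assay, at which 3 of the 3 values shown sit.

The compounds shown leave open which change to the shared core, if any, would give a measurable value instead of a limit.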